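The source may hold more compounds than are shown below. What is called first, only, known or untested is meant among the compounds shown, and "the series" means these compounds.

Values measured so far in a functional assay on MDA-MB-231 cells (Homo sapiens) for antiproliferative activity, read by sulforhodamine B assay, with a stated time of 48 h (a higher number here means a weaker inhibitor of growth, a lower number a stronger inhibitor of growth), are:

- Compound 1 `CCCCCCc1cn(CCCN2C(=O)COc3ccccc32)nn1` gives 1100 nM
- Compound 2 `O=C1COc2ccccc2N1CCCn1cc(-c2ccccn2)nn1` gives 4800 nM
- Compound 3 `CCCCc1cn(CCCN2C(=O)COc3ccccc32)nn1` gives 3600 nM

The value of compound 3 lies within the scatter of the value of compound 2, while compound 1 stands clearly lower than both. Compound 4 `O=C1COc2ccccc2N1CCCn1cc(CCCCl)nn1` keeps the shared core and alters only the end of the side chain (chloro in place of methyl on a saturated chain carbon, three bonds along the chain from an aromatic carbon): chloro in place of methyl on a saturated chain carbon, three bonds along the chain from an aromatic carbon. Butyl thus becomes 3-chloropropyl.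

Within the data shown here, no measured step tests a chloro group directly. The closest guides are changes to the same side group. Going from hexyl to butyl gave a modest 3.3-fold higher number from compound 1 to compound 3 (0.51 log units; beyond the scatter) and going from pyridin-2-yl to butyl gave a 1.3-fold lower number from compound 2 to compound 3 (0.12 log units; within the scatter) and stayed within the scatter. Both replaced more of the group than this swap does, so no shift beyond the scatter is expected in this assay and neither direction is favoured. The estimated change is a 1.2-fold lower number from compound 3 to compound 4 (0.08 log units; within the scatter) and remains a rough expectation. For compound 4 the estimated value is 3000 nM with an expected range of 1200 nM to 7000 nM for this measurement.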

Compound 4, concentration for 50% growth inhibition: 6400 nM
Beside the measured number, compound 4's estimate is 2.1-fold (0.33 log units) below it; the measured number falls inside the stated range.
By their numbers in this assay, from the lowest: compound 1; then compounds 3, 2 and 4 (each within the scatter of the next).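

In this assay, chloro in place of methyl at this chain end gives a 1.8-fold higher number from compound 3 to compound 4 (0.25 log units; within the scatter), so this swap on a saturated chain carbon, three bonds along the chain from an aromatic carbon, does not separate 3-chloropropyl from butyl. The replacement of pyridin-2-yl by 3-chloropropyl also stays within the scatter, with a 1.3-fold higher number from compound 2 to compound 4 (0.12 log units; within the scatter), while the longer hexyl group of compound 1 stands apart, as a 5.8-fold higher number from compound 1 to compound 4 (0.76 log units; beyond the scatter) shows, and among these four side groups only hexyl gives a clearly different number. Nothing measured here explains why compound 1 differs from the other three.

On these data alone, it remains open whether a longer chain such as octyl would take the number lower than hexyl does. Also open, as far as these compounds go, is how an amine or a carboxylic acid at the end of the chain would compare with chloro.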